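Methyl for isopropyl on the pyrrolidine amine nitrogen

The source may hold more compounds than are shown below. What is called first, only, known or untested is meant among the compounds shown, and "the series" means these compounds.

Three compounds of the series have numbers in an assay on isolated protein for inhibition of cathepsin S (Homo sapiens); on this read-out higher numbers stand for weaker inhibition and lower numbers for stronger inhibition. Compound 1 `N#C[C@@]1(NC(=O)[C@@H](CC(=O)N2CCOCC2)CC2CCC(c3ccccc3)CC2)CCN(C2CCCCC2)C1` gives 3140 nM. Among the compounds with values here, compound 3 `N#C[C@@]1(NC(=O)[C@@H](CC(=O)N2CCOCC2)CC2CCc3ccccc3C2)CCN(C2CCCCC2)C1` gives 1.9 nM; the one recorded step, a 1700-fold lower number from compound 1 to compound 3 (3.22 log units; beyond the scatter), concerns the group on the saturated chain carbon and not the amine nitrogen. Within the data shown here, compound 2 `CC(C)N1CC[C@@](C#N)(NC(=O)[C@@H](CC(=O)N2CCOCC2)CC2CCCCC2)C1` gives 66 nM and stands second highest of the three numbers, between compound 3 and compound 1 and beyond the scatter from both; no step to either is recorded, since compound 2 differs from each in more than one place.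

Compound 4 `CN1CC[C@@](C#N)(NC(=O)[C@@H](CC(=O)N2CCOCC2)CC2CCCCC2)C1` is the next member. Its difference from compound 2 is methyl in place of isopropyl on an amine nitrogen in a ring. Among the measured compounds shown here, no measured pair in the set varies the group on this amine nitrogen, so the step from compound 1 to compound 3 gives no direct guidance, and the size of the change is read only from the loss of two carbons of a small group.

With nothing in the data pointing either way, a modest move toward a higher number in this assay is expected, though a step within the scatter remains possible. For compound 4 the expected step is a 2.3-fold higher number from compound 2 to compound 4 (0.36 log units; beyond the scatter). Compound 4 is estimated at 150 nM, with a range of 40 nM to 600 nM.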

Compound 4, half-maximal inhibitory concentration: 155 nM
For compound 4 the middle estimate is 1.0-fold (0.01 log units) below the measured one, within the range that was stated.
By their numbers in this assay, from the lowest: compound 3; then compound 2; then compound 4; then compound 1.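

In this assay, the group on the amine nitrogen in the five-membered ring now has a measured pair of its own: a 2.3-fold higher number from compound 2 to compound 4 (0.37 log units; beyond the scatter), a modest step but one beyond the scatter, with methyl for isopropyl as the only difference. The position, two ring bonds from the ring atom that bears a cyano group, therefore registers in this read-out, with the smaller methyl giving the weaker inhibition in this one pair, though the change is far smaller than a 1700-fold lower number from compound 1 to compound 3 (3.22 log units; beyond the scatter) at the saturated chain carbon. The data offer no measurement that accounts for the step at the amine nitrogen.

The compounds shown leave open how a hydrogen, an ethyl group or a cyclopropyl ring on this nitrogen would read, and where cyclohexyl, carried there by compound 1 and compound 3, would fall against isopropyl and methyl with the chain group held constant. Also open, on these data alone, is whether the methyl for isopropyl step keeps its size when 1,2,3,4-tetrahydronaphthalen-2-yl replaces the cyclohexyl group on the chain.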